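The source may hold more compounds than are shown below. What is called first, only, known or untested is meant among the compounds shown, and "the series" means these compounds.

Working notes on the series, read in an ADME assay on NHDF cells (Homo sapiens) for cytotoxicity, read by MTT assay, with a stated time of 72 h; on this read-out lower numbers stand for stronger inhibition and higher numbers for weaker inhibition. Compound 1 `COc1ccc(/C=C2\CCC/C(=C\c3cccc(Cl)c3)C2=O)cc1OC` gives 11900 nM, compound 2 `COc1ccc(/C=C2\CCC/C(=C\c3ccc(Cl)cc3)C2=O)cc1OC` gives 11200 nM, and compound 3 `COc1ccccc1/C=C1\CCC/C(=C\c2ccc(OC)c(OC)c2)C1=O` gives 18100 nM. Compound 3 therefore sits level with the other two within the scatter, as a 1.5-fold higher number from compound 1 to compound 3 (0.18 log units; within the scatter) and a 1.6-fold higher number from compound 2 to compound 3 (0.21 log units; within the scatter) show.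

The next compound is compound 4 `COc1ccc(/C=C2\CCC/C(=C\c3ccc(O)cc3)C2=O)cc1OC`. The change is 4-hydroxyphenyl in place of 2-methoxyphenyl on a double-bonded chain carbon bound to a double-bonded ring carbon.

All three measured steps bear on this change, since each swaps one aryl group at the same place. Alongside the two steps above, a 1.1-fold lower number from compound 1 to compound 2 (0.03 log units; within the scatter) completes the set, and none of the three goes beyond the scatter. Going by the values given here, no measured compound carries the 4-hydroxyphenyl group, so the data give no direct reading of it and the range has to stay wide. On this precedent, no step beyond the scatter is expected in this assay. The estimated move is a 1.4-fold lower number from compound 3 to compound 4 (0.14 log units; within the scatter), which stays within the scatter. For compound 4 the estimate is 13000 nM, with an expected range from 6000 nM to 27000 nM.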

Compound 4, half-maximal inhibitory concentration: 26100 nM
The estimate for compound 4 lay 2.0-fold (0.30 log units) below the measured number, and the stated range covers the measured number.
By their numbers in this assay, from the lowest: compounds 2, 1, 3 and 4 (each within the scatter of the next, the first and the last beyond it).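

In this assay, going by these compounds alone, the 4-hydroxyphenyl group on a double-bonded chain carbon bound to a double-bonded ring carbon gives the first steps at this place that go beyond the scatter, though both are modest: a 2.3-fold higher number from compound 2 to compound 4 (0.37 log units; beyond the scatter) for hydroxy in place of chloro on an aromatic carbon, and a 2.2-fold higher number from compound 1 to compound 4 (0.34 log units; beyond the scatter) for 4-hydroxyphenyl in place of 3-chlorophenyl. Against 2-methoxyphenyl the same group stays level, with a 1.4-fold higher number from compound 3 to compound 4 (0.16 log units; within the scatter) within the scatter, so this place separates some aryl groups but compound 4 cannot be told apart from compound 3. No measurement at hand bears on why these steps take the size they do.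

As far as these compounds go, it remains open whether the separation from the chlorophenyl compounds belongs to the hydroxy group in particular, and a 4-aminophenyl or 4-carboxyphenyl group in place of 4-hydroxyphenyl would test that. From the compounds shown here alone, the rest of the shared core is also unchanged across compounds 1, 2 and 4, so it is open whether the same steps would hold with a different aryl group on the other side.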